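Aryl to benzyl swap on the ring nitrogen: compounds 1 to 3

The source may hold more compounds than are shown below. What is called first, only, known or untested is meant among the compounds shown, and "the series" means these compounds.

Working notes on the series. Compound 1 `CC(C)n1ncc2c(C(=O)NCc3cn(-c4ccc(F)cc4)nn3)cccc21` was tested in a functional assay on HepG2 cells (Homo sapiens) for inhibition, read by MTT assay, with a stated time of 72 h; a lower number here means a stronger inhibitor, a higher number a weaker inhibitor. In this assay compound 1 gives > 40000 nM, which is a limit of the assay and not a number. Compound 2 `CC(C)n1ncc2c(C(=O)NCc3cn(Cc4ccc(C(F)(F)F)cc4)nn3)cccc21` belongs to the same series and carries a benzyl-type group on the ring nitrogen instead of the aryl group of compound 1. In this assay compound 2 likewise gives > 40000 nM, again a limit of the assay rather than a number. Where compound 1 stands is therefore known only as the limit of > 40000 nM in this assay, at which 2 of the 2 values shown sit; no measured step between two measured compounds exists in this set, so nothing shows how a change on that nitrogen moves the read-out.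

Compound 3 `COc1ccc(Cn2cc(CNC(=O)c3cccc4c3cnn4C(C)C)nn2)cc1` differs from compound 1 by 4-methoxybenzyl in place of 4-fluorophenyl on an aromatic nitrogen. Since every value shown is a limit, the step that the limit leaves unreadable from compound 1 to compound 3 is expected to be none beyond the scatter, and the result is expected again to be a limit rather than a number. The estimate for compound 3 in this assay is 45000 nM, with a range from 15000 nM to 150000 nM.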

Compound 3, half-maximal inhibitory concentration: > 40000 nM
Compound 3 gave a limit, no number; the forecaster's own chance of this, stated with the estimate: 80%; the middle value does not contradict the limit.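

In this assay compound 3 gives > 40000 nM as a limit of the assay and not a number, so the steps from compound 1 and from compound 2 to compound 3 cannot be read. How the group on the aromatic nitrogen moves the read-out stays open, with no compound shown giving a number: the limit of > 40000 nM in this assay, at which 3 of the 3 values shown sit.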